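Flavone-Benzothiazole Conjugates: Estimating a Hydrazine-Linked Analogue

The compounds below may be only part of what the source reports. "The series", "measured", "known", "first", "only" and "open" are said of these compounds alone.

Measured compounds in a functional assay on SK-OV-3 cells (Homo sapiens) for cytotoxicity, read by sulforhodamine B assay, with a stated time of 48 h; on this read-out higher numbers stand for weaker inhibition and lower numbers for stronger inhibition:
compound 1 `O=c1cc(-c2ccccc2)oc2cc(OCCCCNc3nc4ccc(Br)cc4s3)cc(O)c12` gives 35.1 ug/mL
compound 2 `O=c1cc(-c2ccccc2)oc2cc(OCCCCNc3nc4ccc(I)cc4s3)cc(O)c12` gives 56.4 ug/mL
compound 3 `O=C(O)c1ccc2nc(NCCCCOc3cc(O)c4c(=O)cc(-c5ccccc5)oc4c3)sc2c1` gives 43.3 ug/mL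

Compound 3 stands second highest of the three numbers; its nearest neighbour is compound 1, with a 1.2-fold higher number from compound 1 to compound 3 (0.09 log units; within the scatter), and compound 2 differs by a 1.3-fold lower number from compound 2 to compound 3 (0.11 log units; within the scatter). Both steps are within the scatter, as is a 1.6-fold higher number from compound 1 to compound 2 (0.21 log units; within the scatter), so the three measured compounds are indistinguishable on this assay.

Compound 4 `O=c1cc(-c2ccccc2)oc2cc(OCCCCNNc3nc4ccccc4s3)cc(O)c12` differs from compound 3 by (1,3-benzothiazol-2-yl)amino in place of 6-carboxy-1,3-benzothiazol-2-yl on an amine nitrogen. For the measured compounds named here, no measured step bears directly on this change: the measured steps only exchange a single substituent on the benzothiazole. Those steps were all within the scatter, so no step beyond the scatter is expected in this assay. Compound 4 is therefore expected to give 45 ug/mL, with a range from 20 ug/mL to 100 ug/mL. The expected step is a 1.0-fold higher number from compound 3 to compound 4 (0.02 log units; within the scatter).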

Compound 4, half-maximal inhibitory concentration: 51.7 ug/mL
The estimate for compound 4 lay 1.1-fold (0.06 log units) below the measured number; low and high end bracket the measured number.
By their numbers in this assay, from the lowest: compounds 1, 3, 4 and 2 (each within the scatter of the next).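

In this assay, placing (1,3-benzothiazol-2-yl)amino on the amine nitrogen altered the link itself, not just a substituent, yet it gave a 1.2-fold higher number from compound 3 to compound 4 (0.08 log units; within the scatter) and a 1.1-fold lower number from compound 2 to compound 4 (0.04 log units; within the scatter) and a 1.5-fold higher number from compound 1 to compound 4 (0.17 log units; within the scatter). Even this change at the amine nitrogen therefore leaves compound 4 indistinguishable from the other three compounds. Nothing measured here offers an explanation for this. The compounds shown leave open whether a carboxylic acid or a bromo group on the compound 4 scaffold would alter its number. They also leave open whether a longer chain on the amine nitrogen would produce a step beyond the scatter.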